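Swapping imidazol-1-yl for pyridin-3-yl on a thromboxane synthase inhibitor

The source may report more compounds than this note shows. Statements on the series, on what has been measured and on what is new or still open speak of the compounds shown alone.

Measured compounds in a functional assay on microsomes from aorta for inhibition of Thromboxane-A synthase (Homo sapiens), in the presence of a further agent that is not named here; a higher number here means a weaker inhibitor, a lower number a stronger inhibitor: compound 1 `C/C(=C/c1ccc(Cc2cccnc2)n1-c1ccccc1)C(=O)O` gives 24000 nM; compound 2 `CCn1c(/C=C(/C)C(=O)O)ccc1Cc1cccnc1` gives 42 nM; compound 3 `C/C(=C/c1ccc(Cn2ccnc2)n1C)C(=O)O` gives 1000 nM.

Compound 3 stands second highest of the three, with compound 2 a good deal lower and compound 1 a good deal higher. Within the data shown here, the only measured step, a 570-fold lower number from compound 1 to compound 2 (2.76 log units; beyond the scatter), concerns a substituent on an aromatic nitrogen and does not touch the change at hand. Compound 4 `C/C(=C/c1ccc(Cc2cccnc2)n1C)C(=O)O` arises from compound 3 by pyridin-3-yl in place of 1H-imidazol-1-yl on a saturated chain carbon bound to an aromatic carbon. Among the measured compounds shown here, no measured step bears directly on this swap; the one point of reference is that compound 2 carries the same pyridin-3-yl group and gives 42 nM. A step of a 13-fold lower number from compound 3 to compound 4 (1.10 log units; beyond the scatter) toward a lower number is therefore expected in this assay. Compound 4 is estimated at 80 nM, within 20 nM to 400 nM.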

Compound 4, half-maximal inhibitory concentration: 50 nM
For compound 4 the middle estimate is 1.6-fold (0.20 log units) above the measured one, within the range that was stated.
By their numbers in this assay, from the lowest: compounds 2 and 4 (each within the scatter of the next); then compound 3; then compound 1.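

In this assay, pyridin-3-yl in place of 1H-imidazol-1-yl on a saturated chain carbon bound to an aromatic carbon is now measured directly, giving a 20-fold lower number from compound 3 to compound 4 (1.30 log units; beyond the scatter). On the aromatic nitrogen, ethyl and methyl cannot be told apart, with a 1.2-fold higher number from compound 2 to compound 4 (0.08 log units; within the scatter), while methyl in place of phenyl gives a 480-fold lower number from compound 1 to compound 4 (2.68 log units; beyond the scatter), so phenyl stands apart from both smaller groups. Nothing available explains these steps.

As far as these compounds go, it remains open how pyridin-4-yl would read at the same place, and whether a propyl group on the aromatic nitrogen would match ethyl and methyl.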